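Cyanoguanidine side chains on a shared pyridazinone core

The compounds below may be only part of what the source reports. "The series", "measured", "known", "first", "only" and "open" are said of these compounds alone.

Measured compounds:
compound 1 `CN(C)/C(=N/CCCCn1nc(-c2ccccc2)ccc1=O)NC#N` — 80.7%
compound 2 `N#CNC(=N)NCCCCCCn1nc(-c2ccccc2)ccc1=O` — 20.5%

In a functional assay on the whole organism with Rattus norvegicus as the target, at a dose of 100 mg/kg (on this read-out lower numbers stand for less inhibition and higher numbers for more inhibition at the one dose given (going by the name of the read-out)), compound 1 gives 80.7%, while compound 2 gives 20.5%. Compound 2 therefore stands lowest of the two numbers in this assay, with compound 1 the nearest neighbour and a number higher beyond the scatter. Going by the values given here, the one step between the two is a number 60.2 percentage points lower from compound 1 to compound 2 (beyond the scatter), a swap of one chain-borne group for another of the same atom count.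

Compound 3 `N#CNC(=N)NCCCCn1nc(-c2ccccc2)ccc1=O` is not yet measured. It differs from compound 2 by a group of 6 heavy atoms (2 carbon, 4 nitrogen; no ring) in place of a group of 8 heavy atoms (4 carbon, 4 nitrogen; no ring), on a saturated chain carbon, four bonds along the chain from an aromatic nitrogen. Among the compounds with values here, the only measured step, from compound 1 to compound 2, bears on it indirectly: it shows that a change in the chain-borne group at this place can move the read-out by a large amount, and compound 3 carries a group that brings it closer in atom count to compound 1. The direction is uncertain, so a rise is expected for compound 3 relative to compound 2, estimated as a number 29.5 percentage points higher from compound 2 to compound 3 (beyond the scatter), though with a wide range. The estimate for compound 3 in this assay is 50%, expected between 20% and 80%.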

Compound 3, a percentage reported as inhibition, in the whole organism at one dose (the size of the read-out at that dose, not a potency): 61.2%
Compound 3: middle estimate off by 11.2 percentage points, on the low side, and the stated range covers the measured number.
By their numbers in this assay, from the lowest: compound 2; then compound 3; then compound 1.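

Working notes on the chain-borne group: in this assay, the step is large, a number 40.7 percentage points higher from compound 2 to compound 3 (beyond the scatter), when a group of 6 heavy atoms (2 carbon, 4 nitrogen) replaces one of 8 heavy atoms (4 carbon, 4 nitrogen) on a saturated chain carbon, four bonds along the chain from an aromatic nitrogen, while the counted donors, acceptors, double bonds and triple bonds stay the same. The same kind of swap gives only a modest change, a number 19.5 percentage points lower from compound 1 to compound 3 (beyond the scatter), so heavy-atom count alone does not order these compounds: compound 1 and compound 2 share a count yet stand at opposite ends, and compound 3, with the smaller group, lies between them. No measurement available here accounts for these differences.

The three compounds do not show how the read-out responds to a longer chain, or to a plain amine or carboxylic acid in place of the cyanoguanidine end. With one dose in one assay, they also leave open whether the order would hold at other doses.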